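Solubility notes on the imidazopyrazine amide series

The source may report more compounds than this note shows. Statements on the series, on what has been measured and on what is new or still open speak of the compounds shown alone.

Compound 1 `CNC(=O)c1ccc(-c2cnc3cnc(C(=O)N(C)c4ccc(C#N)cc4)cn23)cc1` gives 430000 nM in a physicochemical assay for solubility, measured as thermodynamic solubility, at pH 6.8; on this read-out higher numbers stand for higher solubility and lower numbers for lower solubility. Compound 2 `CN(C(=O)c1cn2c(-c3ccc(C(N)=O)cc3)cnc2cn1)c1ccc(F)cc1` gives 170000 nM in this assay. Of the two numbers in hand, compound 1 stands highest, and the gap to compound 2 is beyond the scatter. For the measured compounds named here, no pair of measured compounds differs in one place, so no measured step guides the next change. Compound 3 `CN(C(=O)c1cn2c(-c3ccc(-c4nnc(N)s4)cc3)cnc2cn1)c1ccc(C#N)cc1` differs from compound 1 in one place: 5-amino-1,3,4-thiadiazol-2-yl in place of methylcarbamoyl on an aromatic carbon. With no measured step of this kind in the series, the direction is uncertain; a move to lower solubility of moderate size, beyond the scatter, is the working expectation, though a result within the scatter of compound 1 cannot be ruled out. The expected step from compound 1 to compound 3 is a 4.3-fold lower number from compound 1 to compound 3 (0.63 log units; beyond the scatter). Compound 3 is estimated at 100000 nM, with a range from 30000 nM to 300000 nM.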

Compound 3, solubility: < 5000 nM
Compound 3: no number, only a limit; the forecaster's own chance of this, stated with the estimate: 5%; middle value at least 20-fold (1.30 log units) from the limit.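

In this assay compound 3 gives < 5000 nM as its reading, which is a limit of the assay and not a number. For the compounds shown here, replacing methylcarbamoyl with 5-amino-1,3,4-thiadiazol-2-yl on an aromatic carbon, para to a large group, gives an at least 86-fold lower number from compound 1 to compound 3 (1.93 log units; beyond the scatter) as the only one-place step in hand, so a single change at this position can move this read-out by a large margin. The full size of the step stays unknown, as only its minimum can be read: the limit of < 5000 nM in this assay, at which 1 of the 3 values shown sits.

A single step cannot separate the contribution of the thiadiazole ring from that of its amino group. As far as these compounds go, how a carboxylic acid or a simple amine would read at this position also remains open, as does whether the step would carry over to other amide groups on the shared core.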